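Methyl to carbamoyl: a small swap, an open question

A few compounds are considered here, and "the series" means these few. Any claim that something is new, unique, unknown or untested is made for them only; others in the source may bear on it.

In a functional assay (aorta) with Rattus norvegicus as the target, in the presence of a further agent that is not named here (on this read-out lower numbers stand for an effect already at smaller amounts and higher numbers for an effect only at larger amounts of compound), compound 1 `COC(=O)C1=C(C)N=C(C)/C(=C(\O)OC)C1c1cccc([N+](=O)[O-])c1` gives 3.4 nM. Compound 2 `COC(=O)C1=C(C)N=C(C)/C(=C(/O)OC)C1c1cccc(OCc2nonc2C)c1` gives 640 nM, a far larger number, so its effect appears only at much larger amounts. Among the compounds with values here, compound 3 `COC(=O)C1=C(C)N=C(C)/C(=C(/O)OC)C1c1cccc(OCc2no[n+]([O-])c2C)c1` gives 500 nM, and compound 2 stands together with it at the upper end of the numbers so far.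

Compound 4 `COC(=O)C1=C(C)N=C(C)/C(=C(/O)OC)C1c1cccc(OCc2nonc2C(N)=O)c1` alters compound 2 in one place: carbamoyl in place of methyl on an aromatic carbon. The (4-methyl-1,2,5-oxadiazol-3-yl)methoxy group thus becomes (4-carbamoyl-1,2,5-oxadiazol-3-yl)methoxy.

Within the data shown here, the only measured step that touches this side group is a 1.3-fold lower number from compound 2 to compound 3 (0.11 log units; within the scatter). It lies within the scatter, but it is a different change, so it is only a loose guide. Among the measured compounds shown here, no measured compound carries carbamoyl. No step beyond the scatter is therefore expected in this assay, in either direction, and the uncertainty is wide. The expected step is a 1.3-fold lower number from compound 2 to compound 4 (0.11 log units; within the scatter). For compound 4 the estimate is 500 nM, with an expected range from 150 nM to 1800 nM.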

Compound 4, half-maximal effective concentration: 3500 nM
Compound 4: middle estimate off by 7.0-fold (0.85 log units), on the low side; the measured number lies above the stated range.
By their numbers in this assay, from the lowest: compound 1; then compounds 3 and 2 (each within the scatter of the next); then compound 4.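

In this assay, within the data shown here, carbamoyl in place of methyl on an aromatic carbon gives a 5.5-fold higher number from compound 2 to compound 4 (0.74 log units; beyond the scatter), so this place on the side group does respond to a change, whereas the only earlier step touching the side group, a 1.3-fold lower number from compound 2 to compound 3 (0.11 log units; within the scatter), showed no such shift. The comparison with the other methyl-bearing compound points the same way, with a 7.0-fold higher number from compound 3 to compound 4 (0.85 log units; beyond the scatter), which leaves compound 4 alone at the high end of the numbers among these side-group compounds. Nothing available here explains why this swap moves the number upward.

A single swap at this carbon cannot show a trend, and only methyl and carbamoyl are seen there. Going by these compounds, how a nitrile, a carboxylic acid or an ethyl group at the same carbon would compare remains open.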